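A few compounds are considered here, and "the series" means these few. Any claim that something is new, unique, unknown or untested is made for them only; others in the source may bear on it.

Measured so far:
compound 1, `CNC(=O)c1cc(C(=O)NC2CC2)cn(Cc2cccc3cc[nH]c23)c1=O`: 11 ug/mL
compound 2, `CNC(=O)c1cc(C(=O)NC2CC2)cn(Cc2ccc(OC)cc2)c1=O`: 263 ug/mL

Both were tested in a physicochemical assay for solubility, read by HPLC, in simulated intestinal fluid, with a stated time of 16 h, tested at 125 ug/mL; on this read-out lower numbers stand for lower solubility and higher numbers for higher solubility. Going by the values given here, compound 1 stands at the lowest of the two numbers; its only neighbour is compound 2, reached through the step of a 24-fold higher number from compound 1 to compound 2 (1.38 log units; beyond the scatter). The unmeasured compound 3, `CNC(=O)c1cc(C(=O)NC2CC2)cn(Cc2cccc3c2CCN3)c1=O`, differs from compound 1 in one place: 2,3-dihydro-1H-indol-4-yl in place of 1H-indol-7-yl on a saturated chain carbon bound to an aromatic nitrogen. Among the compounds with values here, the one measured step bears on this change only loosely. Within the data shown here, it shows that swapping the group on the saturated chain carbon bound to the aromatic nitrogen can move the read-out a great deal, but the group entering compound 3 is not the one that entered compound 2. The change keeps the one hydrogen-bond donor, turns the five-membered ring non-aromatic and adds one hydrogen-bond acceptor. A rise beyond the scatter is therefore expected, though smaller than the step to compound 2. Compound 3 is expected to give 45 ug/mL, within 14 ug/mL to 150 ug/mL. This estimate means an expected step of a 4.1-fold higher number from compound 1 to compound 3 (0.61 log units; beyond the scatter).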

Compound 3, solubility: 100 ug/mL
Beside the measured number, compound 3's estimate is 2.2-fold (0.35 log units) below it, within the range that was stated.
By their numbers in this assay, from the lowest: compound 1; then compound 3; then compound 2.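

Replacing 1H-indol-7-yl with 2,3-dihydro-1H-indol-4-yl on a saturated chain carbon bound to an aromatic nitrogen leaves the counts of heavy atoms and hydrogen-bond donors unchanged, yet in this assay it gives a 9.1-fold higher number from compound 1 to compound 3 (0.96 log units; beyond the scatter). The read-out at this position can therefore move beyond the scatter even when the entering group matches the leaving one in these counts, which the earlier swap to the quite different 4-methoxyphenyl could not show. The 4-methoxyphenyl group still keeps a lead, with a 2.6-fold lower number from compound 2 to compound 3 (0.42 log units; beyond the scatter), and no measurement at hand explains either step.

The entering group differs from the leaving one in two ways at once, since its five-membered ring is non-aromatic and it is a 4-yl rather than a 7-yl, so 1H-indol-4-yl would be needed to tell these two changes apart. Also open, from the compounds shown here alone, is how the read-out would respond to an amine or a carboxylic acid carried on the group at this position.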